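Notes on acid ceramidase series: compound 2 to compound 4

The compounds below may be only part of what the source reports. "The series", "measured", "known", "first", "only" and "open" are said of these compounds alone.

For the measured compounds named here, compound 2, `CN1CCN(c2ccc3c(c2)oc(=O)n3C(=O)NCCCCc2ccccc2)CC1=O`, gives the lowest number among the three measured members in an assay on HEK293 cells for inhibition of acid ceramidase (Homo sapiens), read by fluorescence, with stated times of 10 min and 3 h (a higher number here means a weaker inhibitor, a lower number a stronger inhibitor), where compound 2 gives 92 nM. The nearest measured compound is compound 3, `O=C(NCCCCc1ccccc1)n1c2c(oc1=O)CCN(Cc1ccccc1)C2`, which in this assay gives 436 nM, a gap beyond the scatter. Compound 1, `CC(C)CNC(=O)n1c(=O)oc2cc(C3CCCCN3C)ccc21`, is furthest, giving 1010 nM in this assay, also beyond the scatter. Compound 4, `CC(C)CN1CCC(c2ccc3c(c2)oc(=O)n3C(=O)NCCCCc2ccccc2)CC1`, is not yet measured. It differs from compound 2 as follows: 1-isobutylpiperidin-4-yl in place of 4-methyl-3-oxopiperazin-1-yl on an aromatic carbon. Going by the values given here, no measured pair shows this change, so its size is uncertain. For compound 4 a moderate weakening against compound 2 is expected, with the step from compound 2 to compound 4 estimated at a 2.2-fold higher number from compound 2 to compound 4 (0.34 log units; beyond the scatter). Compound 4 is therefore estimated at 200 nM in this assay, within a range from 60 nM to 700 nM.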

Compound 4, half-maximal inhibitory concentration: 120 nM
The estimate for compound 4 lay 1.7-fold (0.22 log units) above the measured number, within the range that was stated.
By their numbers in this assay, from the lowest: compounds 2 and 4 (each within the scatter of the next); then compound 3; then compound 1.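

In this assay, a 1.3-fold higher number from compound 2 to compound 4 (0.12 log units; within the scatter), with 1-isobutylpiperidin-4-yl in place of 4-methyl-3-oxopiperazin-1-yl on this aromatic carbon. The position therefore does not depend on the ring carbonyl of the group that leaves: a group of 10 heavy atoms, nine of them carbon, gives a number that cannot be told apart. Nothing available explains this result.

Open, on these data alone, is whether a much smaller group on this aromatic carbon, such as a primary amine or a carboxylic acid, would give a number of this size.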